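Methylating the Selenium of Compound 2

This account rests on a few compounds, and the source may have more. Where it says the series, first, only, none or still open, it means among the compounds named here.

Values in a functional assay on CCRF-CEM cells (Homo sapiens) for cytotoxicity, read by MTT assay, with a stated time of 72 h (a lower number here means a stronger inhibitor of growth, a higher number a weaker inhibitor of growth), for the three measured compounds:
Compound 1, `COc1ccc(CNc2nc([SeH])nc3ccccc23)cc1`: compound 1 gives > 100000 nM, a limit of the assay and not a number.
Compound 2, `CSc1ccc(CNc2nc([SeH])nc3ccccc23)cc1`: compound 2 gives 71900 nM.
Compound 3, `[SeH]c1nc(NCc2ccccc2)c2ccccc2n1`: compound 3 gives > 100000 nM, again a limit of the assay.

Within the data shown here, compound 2 thus holds the only number among the three; the other two values sit at the limit of > 100000 nM in this assay, at which 2 of the 3 values shown sit. The steps measured so far are an at least 1.3-fold lower number from compound 1 to compound 2 (0.14 log units; that floor lies within the scatter), an at least 1.3-fold higher number from compound 2 to compound 3 (0.14 log units; that floor lies within the scatter) and a step that the two limits leave unreadable from compound 1 to compound 3. All three change the group on the aromatic carbon of the benzyl ring and leave the selenium untouched.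

Compound 4, `CSc1ccc(CNc2nc([Se]C)nc3ccccc23)cc1`, differs from compound 2 only by methyl in place of hydrogen on a selenium. Among the measured compounds shown here, no measured step touches this position, so none of them bears on the change directly. The expectation is therefore set close to compound 2 itself, with a wide spread: the estimated step is a 1.2-fold lower number from compound 2 to compound 4 (0.08 log units; within the scatter). Compound 4 is expected to give about 60000 nM, within 15000 nM to 200000 nM.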

Compound 4, concentration for 50% growth inhibition: 48700 nM
Compound 4: middle estimate off by 1.2-fold (0.09 log units), on the high side; the range from low to high includes it.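

Compound 4 is the first compound shown in which the selenium carries something other than hydrogen, and in this assay the change is a 1.5-fold lower number from compound 2 to compound 4 (0.17 log units; within the scatter). In this one pair, then, a methyl can take the place of hydrogen on the selenium without a step beyond the scatter, so the hydrogen on this atom is not needed to keep a measurable number. Like compound 2, compound 4 gives a number and does not sit at the limit reached by the other two compounds: the limit of > 100000 nM in this assay, at which 2 of the 4 values shown sit.

From the compounds shown here alone, it remains open whether a longer chain on the selenium, or one ending in an amine or a carboxylic acid, would move the number beyond the scatter. Going by these compounds, it is also open whether methyl on the selenium would give a readable step with methoxy or hydrogen in place of the methylsulfanyl on the benzyl ring.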